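Adding a hydroxymethyl to the dioxolane side chain

A few compounds are considered here, and "the series" means these few. Any claim that something is new, unique, unknown or untested is made for them only; others in the source may bear on it.

- Compound 1 `O=C1c2c[n+]([O-])c3ccccc3c2C(=O)c2c1c1ccccc1n2Cc1cn([C@@H]2C[C@H](O)[C@@H](CO)O2)nn1`: 120 nM
- Compound 2 `CC1(C)OCC(Cn2cc(Cn3c4c(c5ccccc53)C(=O)c3c[n+]([O-])c5ccccc5c3C4=O)nn2)O1`: 80 nM

For the measured compounds named here, in a functional assay on A549 cells (Homo sapiens) for cytotoxicity, read by MTT assay, with a stated time of 72 h (a lower number here means a stronger inhibitor, a higher number a weaker inhibitor), compound 2 stands within the scatter of compound 1, the only other compound measured so far. Compound 3 `CC1(C)O[C@@H](CO)[C@H](Cn2cc(Cn3c4c(c5ccccc53)C(=O)c3c[n+]([O-])c5ccccc5c3C4=O)nn2)O1` keeps the core of compound 2 and alters one group: 5-(hydroxymethyl)-2,2-dimethyl-1,3-dioxolan-4-yl in place of 2,2-dimethyl-1,3-dioxolan-4-yl on a saturated chain carbon bound to an aromatic nitrogen. In words, 5-(hydroxymethyl)-2,2-dimethyl-1,3-dioxolan-4-yl takes the place of 2,2-dimethyl-1,3-dioxolan-4-yl. Going by the values given here, no measured step makes this exact change. The nearest guide is a 1.5-fold lower number from compound 1 to compound 2 (0.18 log units; within the scatter), which removed a group that also holds a hydroxymethyl, 4-hydroxy-5-(hydroxymethyl)oxolan-2-yl. That single step stayed within the scatter, so no change beyond the scatter is expected here. The expected step is a 1.3-fold higher number from compound 2 to compound 3 (0.10 log units; within the scatter). For compound 3 the estimated value in this assay is 100 nM, with an expected range of 40 nM to 250 nM.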

Compound 3, half-maximal inhibitory concentration: 370 nM
Beside the measured number, compound 3's estimate is 3.7-fold (0.57 log units) below it; measured number above the stated range.
By their numbers in this assay, from the lowest: compounds 2 and 1 (each within the scatter of the next); then compound 3.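

For the compounds shown here, at this saturated chain carbon bound to an aromatic nitrogen, the side chain does affect the number: in this assay, 5-(hydroxymethyl)-2,2-dimethyl-1,3-dioxolan-4-yl in place of 2,2-dimethyl-1,3-dioxolan-4-yl gives a 4.6-fold higher number from compound 2 to compound 3 (0.67 log units; beyond the scatter), the first step in this set beyond the scatter. Holding a hydroxymethyl does not alone fix the number: swapping 4-hydroxy-5-(hydroxymethyl)oxolan-2-yl for (5-(hydroxymethyl)-2,2-dimethyl-1,3-dioxolan-4-yl)methyl, two groups that both hold one, gives a 3.1-fold higher number from compound 1 to compound 3 (0.49 log units; beyond the scatter), also beyond the scatter. Nothing measured here accounts for these steps.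

From the compounds shown here alone, how an amine or a carboxylic acid in place of the hydroxymethyl would read in this assay remains open. So does the effect of the opposite arrangement at the 2 defined stereocentres of the entering group.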